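Swapping the benzyl substituent on a weak topoisomerase inhibitor

A few compounds are considered here, and "the series" means these few. Any claim that something is new, unique, unknown or untested is made for them only; others in the source may bear on it.

Compound 1 `COc1c(N2CC[C@@H](CN)C2)c(F)cc2c(=O)c(C(=O)O)cn(Cc3ccc(-n4cccn4)cc3)c12` is the starting point. In an assay on isolated protein for inhibition of DNA topoisomerase 1 (Homo sapiens), with a stated time of 15 min (on this read-out higher numbers stand for weaker inhibition and lower numbers for stronger inhibition), compound 1 gives > 200000 nM, which is a limit of the assay and not a number, so only an upper bound on its inhibition is known (the limit of > 200000 nM in this assay, at which 1 of the 3 values shown sits). Two changes to compound 1 have been measured. Compound 2 `NC[C@@H]1CCN(c2cc3c(cc2F)c(=O)c(C(=O)O)cn3Cc2ccc(-n3cccn3)cc2)C1` gives 91600 nM in this assay, and the step of an at least 2.1-fold lower number from compound 1 to compound 2 (0.33 log units; beyond the scatter) shows a move toward stronger inhibition. Compound 3 `COc1c(N2CC[C@@H](CN)C2)c(F)cc2c(=O)c(C(=O)O)cn(Cc3ccc(-c4ccc(F)cc4)cc3)c12` gives 60900 nM, and the step of an at least 3.2-fold lower number from compound 1 to compound 3 (0.51 log units; beyond the scatter) likewise moves toward stronger inhibition.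

Compound 4 `COc1c(N2CC[C@@H](CN)C2)c(F)cc2c(=O)c(C(=O)O)cn(Cc3ccc4ccccc4c3)c12` is not yet measured. It differs from compound 1 by naphthalen-2-yl in place of 4-(1H-pyrazol-1-yl)phenyl on a saturated chain carbon bound to an aromatic nitrogen. For the measured compounds named here, of the measured steps, the one from compound 1 to compound 3 bears most directly on this change, since it also alters the group on the same saturated chain carbon bound to an aromatic nitrogen, and it gave a lower number. The step to compound 2 changes a different part of the molecule but points the same way. A lower number than that of compound 1 is therefore expected, and for compound 4 the step is estimated as an at least 2.8-fold lower number from compound 1 to compound 4 (0.45 log units; beyond the scatter). Compound 4 is expected to give about 70000 nM in this assay, within a range from 25000 nM to 200000 nM.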

Compound 4, half-maximal inhibitory concentration: 43700 nM
The estimate for compound 4 lay 1.6-fold (0.20 log units) above the measured number; the measured number falls inside the stated range.
By their numbers in this assay, from the lowest: compounds 4, 3 and 2 (each within the scatter of the next, the first and the last beyond it). At a limit, above all of these: compound 1.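

In this assay, replacing 4-(1H-pyrazol-1-yl)phenyl with naphthalen-2-yl gives an at least 4.5-fold lower number from compound 1 to compound 4 (0.66 log units; beyond the scatter), so on this saturated chain carbon bound to an aromatic nitrogen, a group with no hydrogen-bond acceptors and only carbon in its aromatic rings can still lower the number. Compound 3 gives 60900 nM and compound 4 gives 43700 nM, values within the scatter of each other, so two different replacements for the same group cannot be told apart in this assay. The true size of the step is unknown because the value of compound 1 is a limit of the assay and not a number: the limit of > 200000 nM in this assay, at which 1 of the 4 values shown sits.

The compounds shown leave open whether a plain benzyl group or a cyclohexylmethyl group, with a saturated ring, would give a similar number at this place, which would show how much of the aromatic group is needed. They also leave open whether hydrogen in place of methoxy on the aromatic carbon of the shared core would lower the number further when combined with (naphthalen-2-yl)methyl.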